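Working notes: sulfonyl in place of carbonyl on the ring nitrogen

The source may hold more compounds than are shown below. What is called first, only, known or untested is meant among the compounds shown, and "the series" means these compounds.

Measured so far:
compound 1 `Cc1ccc(C(=O)Nc2cccc(/C=C/C(=O)c3nc4ccccc4[nH]3)c2)cc1`: 6560 nM
compound 2 `O=C(Nc1cccc(/C=C/C(=O)c2nc3ccccc3[nH]2)c1)c1cc(Cl)cc(Cl)c1`: 3660 nM
compound 3 `Cc1cc(C)cc(C(=O)Nc2cccc(/C=C/C(=O)c3nc4ccccc4[nH]3)c2)c1`: 4020 nM

In a functional assay on 143B cells (Homo sapiens) for antiproliferative activity, read by MTT assay, with a stated time of 48 h (a higher number here means a weaker inhibitor, a lower number a stronger inhibitor), compound 3 gives 4020 nM, the second highest of the three numbers. Its nearest neighbour is compound 2 (a 1.1-fold higher number from compound 2 to compound 3 (0.04 log units; within the scatter)) and its furthest is compound 1 (a 1.6-fold lower number from compound 1 to compound 3 (0.21 log units; within the scatter)); the remaining pair is a 1.8-fold lower number from compound 1 to compound 2 (0.25 log units; within the scatter). Every one of these steps sits within the scatter, so the three compounds cannot be ordered against each other.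

Compound 4 `O=C(/C=C/c1cccc(NS(=O)(=O)c2ccccc2Cl)c1)c1nc2ccccc2[nH]1` is the next candidate. The change from compound 3 is (2-chlorophenyl)sulfonyl in place of (3,5-dimethylphenyl)carbonyl on a nitrogen on an aromatic ring. All three measured steps vary only the substituents on the aromatic ring attached to the carbonyl, and none of them moves the number beyond the scatter. For the measured compounds named here, no measured step touches the carbonyl itself or replaces it by a sulfonyl, so there is no direct precedent for this change. Given that the whole measured set spans less than the scatter, the working expectation is a number near that of compound 3, with a wide range to reflect the untested linker change; the expected step is a 1.1-fold higher number from compound 3 to compound 4 (0.05 log units; within the scatter). Compound 4 is therefore estimated at 4500 nM, between 1500 nM and 15000 nM.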

Compound 4, half-maximal inhibitory concentration: 4790 nM
Compound 4: the middle estimate sits 1.1-fold (0.03 log units) below what was measured, within the range that was stated.
By their numbers in this assay, from the lowest: compounds 2, 3, 4 and 1 (each within the scatter of the next).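

In this assay, the sulfonyl linker on a nitrogen on an aromatic ring gives no step beyond the scatter against any of the three amides (a 1.2-fold higher number from compound 3 to compound 4 (0.08 log units; within the scatter); a 1.3-fold higher number from compound 2 to compound 4 (0.12 log units; within the scatter); a 1.4-fold lower number from compound 1 to compound 4 (0.14 log units; within the scatter)), so the four compounds cannot be ordered against each other. The earlier steps shown here varied only the substituents on the aromatic ring attached to the carbonyl, whereas these show that the carbonyl itself can give way to a sulfonyl, together with a change to 2-chlorophenyl, without a readable change in this read-out. Nothing at hand accounts for this flat result.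

The compounds shown leave open how sulfonyl and carbonyl compare when they carry the same aromatic group, as each of these pairs changes the linker and the ring substituents together. Also open, going by these compounds, is whether a different group on this nitrogen, such as methylsulfonyl, or an aminoethyl chain or a carboxylic acid on the aromatic ring, would give a step beyond the scatter in this assay.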